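The compounds below may be only part of what the source reports. "The series", "measured", "known", "first", "only" and "open" are said of these compounds alone.

Compound 1, `COc1cc2ncnc(N3CCCc4ccccc43)c2cc1NC(=O)/C=C/C(C)C`, gives 8430 nM in a functional assay on PC-3 cells (Homo sapiens) for antiproliferative activity, read by MTT assay, with a stated time of 72 h; on this read-out higher numbers stand for weaker inhibition and lower numbers for stronger inhibition.
Compound 2, `CC(C)/C=C/C(=O)Nc1cc2c(N3CCCc4ccccc43)ncnc2cc1O[C@@H]1CCOC1`, gives 8510 nM.
Compound 3, `COc1cc2ncnc(N3CCCc4ccccc43)c2cc1NC(=O)/C=C/CN1CCN(C)CC1`, gives 6260 nM.

Compound 2 holds the highest of these three numbers, but only barely: a 1.0-fold higher number from compound 1 to compound 2 (0.00 log units; within the scatter), and the number of compound 3 lies close enough to that of compound 2 that the two cannot be told apart. All three compounds, which share one core, thus stand on a level in this assay.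

Compound 4, `O=C(/C=C/CN1CCC(CO)CC1)Nc1cc2c(N3CCCc4ccccc43)ncnc2cc1O[C@@H]1CCOC1`, is built from compound 2 by one change: (4-(hydroxymethyl)piperidin-1-yl)methyl in place of isopropyl on a double-bonded chain carbon bound to a double-bonded chain carbon. Going by the values given here, one measured step bears on this, the exchange at the same place from compound 1 to compound 3, where a ring-bearing, nitrogen-containing group also replaced the isopropyl: a 1.3-fold lower number from compound 1 to compound 3 (0.13 log units; within the scatter). That step stayed inside the scatter, so the expected step here is a 1.2-fold lower number from compound 2 to compound 4 (0.08 log units; within the scatter), that is, nothing clearly beyond the scatter. Compound 4 is therefore estimated to give about 7000 nM, with a range from 3000 nM to 16000 nM.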

Compound 4, half-maximal inhibitory concentration: 5460 nM
Compound 4: middle estimate off by 1.3-fold (0.11 log units), on the high side, and the stated range covers the measured number.
By their numbers in this assay, from the lowest: compounds 4, 3, 1 and 2 (each within the scatter of the next).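

The step to compound 4 shows that this place on the double-bonded chain carbon accepts a far larger group than isopropyl, one with a six-membered non-aromatic ring and a hydrogen-bond donor, while the number barely moves: a 1.6-fold lower number from compound 2 to compound 4 (0.19 log units; within the scatter) in this assay for this exchange. The earlier exchange at this place was made on a compound with methyl on the oxygen, whereas this one carries oxolan-3-yl there, and both steps stay within the scatter, with no compound shown going against that. No further measurement is available to explain this result.

Still open, going by these compounds, is whether a carboxylic acid or a simple dimethylamino group at this place, or a longer chain leading to the ring, would give a step beyond the scatter. Also open, on these data alone, is how (4-(hydroxymethyl)piperidin-1-yl)methyl behaves with methyl on the oxygen.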